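A few compounds are considered here, and "the series" means these few. Any claim that something is new, unique, unknown or untested is made for them only; others in the source may bear on it.

Measured so far in a physicochemical assay for lipophilicity; a lower number here means a more polar compound, a higher number a more lipophilic compound:
- compound 1 `CC(C)(c1cc([C@@]23CCOC[C@@H]2C3)nc(-c2ccc(NC(=S)NCCO)cc2)n1)S(C)(=O)=O`: 3.9
- compound 2 `CCNC(=O)Nc1ccc(-c2nc(C(C)(C)S(C)(=O)=O)cc([C@@]34CCOC[C@@H]3C4)n2)cc1`: 4.7

Going by the values given here, compound 1 holds the lower of the two numbers, and the only measured step is a number 0.80 log units higher from compound 1 to compound 2 (beyond the scatter). Compound 3 `CC(C)(c1cc([C@]23CCOC[C@H]2C3)nc(-c2ccc(NC(=S)NCCO)cc2)n1)S(C)(=O)=O` has not yet been measured. Its difference from compound 1 is the two compounds have the same atoms and bonds and differ only in configuration as drawn: 2 of 2 stereo elements differ (all stereocentres are inverted: mirror images); a stereocentre at a saturated ring carbon is drawn S in compound 1 and R in compound 3; a stereocentre at a saturated ring carbon is drawn R in compound 1 and S in compound 3.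

The measured step replaces a group on a nitrogen on an aromatic ring and inverts no stereocentre, which leaves it with no direct bearing on this change. Among the compounds with values here, no measured pair shows what inversion does. Mirror images are nevertheless expected to read alike in a measurement of this kind, and no step beyond the scatter is expected in this assay. The value of compound 1, 3.9, therefore serves as the anchor. The expected step is no change at the digits printed from compound 1 to compound 3 (within the scatter). For compound 3 the estimate is 3.9, with an expected range of 3.6 to 4.2.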

Compound 3, partition coefficient: 3.9
For compound 3 middle estimate and measured number coincide at the digits printed, within the range that was stated.
By their numbers in this assay, from the lowest: compounds 1 and 3 (each within the scatter of the next); then compound 2.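

In this assay, inverting both stereocentres at the saturated ring carbons gives no change at the digits printed from compound 1 to compound 3 (within the scatter). Going by these compounds alone, the earlier step, a number 0.80 log units higher from compound 1 to compound 2 (beyond the scatter), replaced a group on a nitrogen on an aromatic ring and left both stereocentres untouched, so this pair is the first direct reading of inversion. Its outcome means that, for this pair, the number tracks the atoms and bonds and not the configuration as drawn, and the comparison is clean because a single kind of difference separates the two compounds: the fact that compounds 1 and 3 differ only in the configuration as drawn.

Going by these compounds, whether the mirror image of compound 2 would also read alike in this assay remains open. Also open, on these data alone, is how that number would respond to an amine or a carboxylic acid as part of the group on that nitrogen.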